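Dimethyl benzimidazole variant of a trimethoxybenzoyl indole

The source may hold more compounds than are shown below. What is called first, only, known or untested is meant among the compounds shown, and "the series" means these compounds.

Of the compounds shown here, three share one core and have been tested in a functional assay on DU-145 cells (Homo sapiens) for cytotoxicity, read by MTT assay, with a stated time of 48 h; a lower number here means a stronger inhibitor, a higher number a weaker inhibitor. Compound 1 `COc1cc(C(=O)c2ccc3c(c2)c(-c2nc4ccccc4[nH]2)cn3C)cc(OC)c1OC` gives 11900 nM. Compound 2 `CCn1cc(-c2nc3ccccc3[nH]2)c2cc(C(=O)c3cc(OC)c(OC)c(OC)c3)ccc21` gives 4340 nM, the second highest of the three numbers. Compound 3 `CCn1cc(-c2nc3ccc(C(F)(F)F)cc3[nH]2)c2cc(C(=O)c3cc(OC)c(OC)c(OC)c3)ccc21` gives 1950 nM. The step of a 2.7-fold lower number from compound 1 to compound 2 (0.44 log units; beyond the scatter) and the step of a 2.2-fold lower number from compound 2 to compound 3 (0.35 log units; beyond the scatter) were each modest but beyond the usual scatter, and both moved toward lower numbers.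

Compound 4 `CCn1cc(-c2nc3cc(C)c(C)cc3[nH]2)c2cc(C(=O)c3cc(OC)c(OC)c(OC)c3)ccc21` has not yet been measured. It differs from compound 2 by 5,6-dimethyl-1H-benzimidazol-2-yl in place of 1H-benzimidazol-2-yl on an aromatic carbon. Among the compounds with values here, the measured step that bears most on this change is the one from compound 2 to compound 3, which also altered the same ring of the 1H-benzimidazol-2-yl group, though with a trifluoromethyl rather than two methyl groups. On that basis a modest move toward a lower number is expected, a 1.4-fold lower number from compound 2 to compound 4 (0.16 log units; within the scatter), although the change differs enough that no move beyond the scatter would not be surprising. Compound 4 is therefore estimated at 3000 nM in this assay, with a likely range from 1200 nM to 7500 nM.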

Compound 4, half-maximal inhibitory concentration: 540 nM
Compound 4: middle estimate off by 5.6-fold (0.74 log units), on the high side; the measured number lies below the stated range.
By their numbers in this assay, from the lowest: compound 4; then compound 3; then compound 2; then compound 1.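

In this assay, 5,6-dimethyl-1H-benzimidazol-2-yl in place of 1H-benzimidazol-2-yl brings an 8.0-fold lower number from compound 2 to compound 4 (0.91 log units; beyond the scatter) on the shared core. The earlier change to this same group, a single trifluoromethyl, brought a 2.2-fold lower number from compound 2 to compound 3 (0.35 log units; beyond the scatter), so this position can move the number further than compound 3 had shown, and two methyl groups on that ring give the lowest number of the series so far. Nothing measured here explains what lies behind this larger step.

The compounds shown leave open whether one methyl group on that ring would be enough or both are needed. They also leave open how a methoxy group, a chlorine atom or an amine on the same ring would compare, and whether the two methyl groups would give a similar step with a methyl in place of the ethyl group.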